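The compounds below may be only part of what the source reports. "The series", "measured", "known", "first", "only" and "open" are said of these compounds alone.

Measured compounds:
Compound 1 `Cc1cc(COc2ccc(Cl)cc2)nc(-c2ccccn2)n1`: 251 nM
Compound 2 `Fc1ccc(OCc2cc(OCC(F)(F)F)nc(-c3ccccn3)n2)c(F)c1F`: 7.94 nM

Both were tested in a functional assay on cells for antagonist activity at Free fatty acid receptor 1 (Homo sapiens), read by TR-FRET and inositol phosphate accumulation, with a stated time of 2 h; a lower number here means a stronger inhibitor, a higher number a weaker inhibitor. Compound 2 gives 7.94 nM, the lower of the two numbers; compound 1 gives 251 nM, a higher number by a gap beyond the scatter, so compound 2 is the stronger inhibitor of the pair.

Compound 3 `N#CCC1(COc2cc(COc3ccc(F)c(F)c3F)nc(-c3ccccn3)n2)COC1` has not been measured. It differs from compound 2 in one place: 3-(cyanomethyl)oxetan-3-yl in place of trifluoromethyl on a saturated chain carbon bound to an oxygen on an aromatic ring. For the measured compounds named here, no pair of measured compounds shows this change, so nothing in the data fixes its size. The expectation rests only on the value of compound 2, 7.94 nM, and on the size of the group exchanged. A small to moderate step toward a higher number, that is toward a weaker inhibitor, is expected from compound 2 to compound 3, a 2.5-fold higher number from compound 2 to compound 3 (0.40 log units; beyond the scatter). For compound 3 the estimate in this assay is 20 nM, with a range from 5 nM to 80 nM.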

Compound 3, half-maximal inhibitory concentration: 398 nM
The estimate for compound 3 lay 20-fold (1.30 log units) below the measured number; the whole stated range lies below it.
By their numbers in this assay, from the lowest: compound 2; then compounds 1 and 3 (each within the scatter of the next).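

At the saturated chain carbon bound to an oxygen on an aromatic ring, the group carried matters a great deal in this assay: 3-(cyanomethyl)oxetan-3-yl in place of trifluoromethyl gives a 50-fold higher number from compound 2 to compound 3 (1.70 log units; beyond the scatter), so this place does not accept every uncharged replacement equally. The entering group differs in several ways at once, bringing a four-membered non-aromatic ring, a triple bond and hydrogen-bond acceptors, and this single step does not separate these features. Nothing available bears on why the number rises.

Still open, from the compounds shown here alone, is whether the oxetane ring or the nitrile goes with the rise. An oxetan-3-yl group lacking the cyanomethyl arm, a cyanomethyl group without the ring, or a plain ethyl chain at this place could each help to settle that.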